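Swapping sec-butyl for isobutyl on an antiproliferative acid

The compounds below may be only part of what the source reports. "The series", "measured", "known", "first", "only" and "open" are said of these compounds alone.

Values in a functional assay on MCF7 cells (Homo sapiens) for antiproliferative activity, read by MTT assay, with a stated time of 48 h; a higher number here means a weaker inhibitor, a lower number a stronger inhibitor:
- Compound 1 `COC(=O)[C@H](CC(C)C)NC(=O)c1ccc(Oc2nc3ccccc3nc2NC(C)(C)C)cc1`: > 50000 nM (a limit of the assay)
- Compound 2 `CC(C)(C)Nc1nc2ccccc2nc1Oc1ccc(C(=O)NCC(=O)O)cc1`: > 50000 nM (a limit of the assay)
- Compound 3 `CC[C@@H](C)[C@H](NC(=O)c1ccc(Oc2nc3ccccc3nc2NC(C)(C)C)cc1)C(=O)O`: 11400 nM

Among the measured compounds shown here, compound 3 holds the only true number. Compound 1 and compound 2 both rest on (the limit of > 50000 nM in this assay, at which 2 of the 3 values shown sit).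

Compound 4 `CC(C)C[C@H](NC(=O)c1ccc(Oc2nc3ccccc3nc2NC(C)(C)C)cc1)C(=O)O` changes one thing relative to compound 3: isobutyl in place of sec-butyl on a saturated chain carbon bound to an amide-type nitrogen and a carbonyl carbon. The two have the same atoms, joined differently, with isobutyl in place of sec-butyl on a saturated chain carbon bound to an amide-type nitrogen and a carbonyl carbon.

For the measured compounds named here, two measured steps bear on this change: an at least 4.3-fold lower number from compound 2 to compound 3 (0.64 log units; beyond the scatter) and an at least 4.3-fold lower number from compound 1 to compound 3 (0.64 log units; beyond the scatter). Going by the values given here, each alters more than the swap at hand, so neither fixes its size, and no measured pair isolates it. In this assay, the expected step is a 1.3-fold higher number from compound 3 to compound 4 (0.12 log units; within the scatter), which means no change beyond the scatter is anticipated. A slide back to the limit remains possible.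

For compound 4 the estimated value is 15000 nM, with an expected range of 6000 nM to 45000 nM.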

Compound 4, half-maximal inhibitory concentration: 40300 nM
Compound 4: middle estimate off by 2.7-fold (0.43 log units), on the low side, and the stated range covers the measured number.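

In this assay, the swap on this saturated chain carbon is not silent: it gives a 3.5-fold higher number from compound 3 to compound 4 (0.55 log units; beyond the scatter), so two groups with the same atoms, sec-butyl and isobutyl, are told apart at this position. The earlier compounds shown here showed only that sec-butyl gave a lower number than hydrogen here, whereas isobutyl in place of hydrogen gives an at least 1.2-fold lower number from compound 2 to compound 4 (0.09 log units; that floor lies within the scatter), and hydrogen in place of methyl on an oxygen next to a carbonyl group gives an at least 1.2-fold lower number from compound 1 to compound 4 (0.09 log units; that floor lies within the scatter). Neither floor shows a change beyond the scatter, since both comparisons rest on a limit: the limit of > 50000 nM in this assay, at which 2 of the 4 values shown sit.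

On these data alone, whether a benzyl group or a longer chain on this carbon would lower the number further remains open. So does the effect of a methyl ester alongside sec-butyl.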